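A few compounds are considered here, and "the series" means these few. Any claim that something is new, unique, unknown or untested is made for them only; others in the source may bear on it.

Compound 2 `Cc1ccc2c(NCc3ccc(NC(=O)C4CCN(Cc5ccc(F)cc5Cl)CC4)cc3)nc(N(C)C)nc2c1` is the point of departure. In a functional assay on SV5A8 cells (Homo sapiens) for cytotoxicity (on this read-out higher numbers stand for weaker inhibition and lower numbers for stronger inhibition), compound 2 gives > 5910 nM, which is a limit of the assay and not a number. Among the measured compounds shown here, compound 1 `COc1ccc(CN2CCC(C(=O)Nc3ccc(CNc4nc(N(C)C)nc5cc(C)ccc45)cc3)CC2)cc1` is the only other member measured. In this assay compound 1 gives > 6180 nM, likewise a limit of the assay. For the measured compounds named here, the one recorded step, a step that the two limits leave unreadable from compound 1 to compound 2, is unreadable for that reason: both ends sit at a limit, as the limit of > 5910 nM in this assay, at which 1 of the 2 values shown sits, and the limit of > 6180 nM in this assay, at which 1 of the 2 values shown sits, state. Compound 3 `Cc1ccc2c(NCc3ccc(NC(=O)C4CCN(Cc5cc(Cl)ccn5)CC4)cc3)nc(N(C)C)nc2c1` differs from compound 2 by 4-chloropyridin-2-yl in place of 2-chloro-4-fluorophenyl on a saturated chain carbon bound to an amine nitrogen in a ring. Going by the values given here, no measured step bears on this exchange of an aromatic ring of carbon only for an aromatic ring with one hetero atom; the only step in hand is the unreadable one, so no size of step can be expected in this assay in either direction, and nothing beyond the scatter is foreseen. Two limits in two compounds give no footing for anything other than a further limit. Compound 3 is therefore estimated at 8000 nM in this assay, with a range from 3000 nM to 30000 nM. The step that the limit leaves unreadable from compound 2 to compound 3 that this estimate implies is expected to be no more than scatter.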

Compound 3, half-maximal inhibitory concentration: > 5400 nM
Compound 3: a limit, no number; the forecaster's own chance of this, stated with the estimate: 80%; the middle value is on the limit's open side.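

Among the compounds shown here, compound 1, compound 2 and compound 3 all stand at limits of the assay in this assay, and no step among them can be read. The compounds shown leave open how far the three truly differ, and whether exchanging the aromatic ring on the saturated chain carbon bound to an amine nitrogen in a ring changes the read-out at all.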